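Trifluoromethyl in place of methyl on the shared core

This account rests on a few compounds, and the source may have more. Where it says the series, first, only, none or still open, it means among the compounds named here.

Of the compounds shown here, three sharing one core have been measured in a functional assay on the whole organism with Mus musculus as the target, with a stated time of 1 h, at a dose of 100 mg/kg by the intraperitoneal route; on this read-out higher numbers stand for more inhibition at the one dose given (going by the name of the read-out) and lower numbers for less inhibition. Compound 1, the unsubstituted parent `c1ccc(COc2nc3ccccc3s2)cc1`, gives 68.8%. Compound 2, `Cc1ccc(COc2nc3ccccc3s2)cc1`, gives 1.95% and stands lowest of the three, far below compound 1 and furthest from compound 3. Compound 3, `Fc1cccc(COc2nc3ccccc3s2)c1`, gives 86.8%.

Two single-point changes are on record. The step of a number 66.9 percentage points lower from compound 1 to compound 2 (beyond the scatter) shows that adding a methyl at this position of the outer ring removes almost all of the inhibition. The step of a number 18 percentage points higher from compound 1 to compound 3 (beyond the scatter) shows that a fluoro at another position of that ring raises it by a modest amount.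

Compound 4, `FC(F)(F)c1ccc(COc2nc3ccccc3s2)cc1`, has not yet been measured. It differs from compound 2 in one place: trifluoromethyl in place of methyl on an aromatic carbon. Among the measured compounds shown here, no measured step tests this exact exchange. For the measured compounds named here, the only step at the same position, from compound 1 to compound 2, was large and downward, so a group here can matter greatly, but nothing shows whether a trifluoromethyl behaves like a methyl or like a hydrogen at that spot. The expected step of a number 23.1 percentage points higher from compound 2 to compound 4 (beyond the scatter) is therefore upward but very uncertain. For compound 4 the estimate is 25%, with a range from 0% to 75%.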

Compound 4, a percentage reported as inhibition, in the whole organism at one dose (the size of the read-out at that dose, not a potency): 12.2%
Compound 4: the middle estimate sits 12.8 percentage points above what was measured; measured number inside the range.
By their numbers in this assay, from the lowest: compound 2; then compound 4; then compound 1; then compound 3.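

In this assay, trifluoromethyl at this position, para to a large group, does not restore the inhibition seen with hydrogen there, with a number 56.6 percentage points lower from compound 1 to compound 4 (beyond the scatter). Exchanging methyl for trifluoromethyl recovers only a small part of what was lost, with a number 10.3 percentage points higher from compound 2 to compound 4 (beyond the scatter). The drop is therefore not peculiar to methyl, since two different groups at this spot both give far less inhibition than hydrogen, although no information is available to explain this for either group.

The compounds shown leave open whether any group at this position can keep or raise the inhibition, for example an amine, a hydroxyl or a carboxylic acid, or whether hydrogen is simply the best of the options here. They also leave open how a methyl or a trifluoromethyl would behave at the position carried by the fluoro of compound 3, and whether a longer chain at either position would follow the same trend.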